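Two isomeric cores, the same swap, all at the limit

The source may report more compounds than this note shows. Statements on the series, on what has been measured and on what is new or still open speak of the compounds shown alone.

Compound 1 `COc1cc(-c2ncnn2-c2ccc([N+](=O)[O-])cc2)cc(OC)c1OC` carries a trimethoxyphenyl group on one core, and compound 2 `COc1cc(-c2ncnn2-c2ccc(Cl)cc2)cc(OC)c1OC` differs from it by a single change (chloro in place of nitro on an aromatic carbon). In a functional assay on Jurkat cells (Homo sapiens) for antiproliferative activity, read by MTT assay, with a stated time of 72 h (a higher number here means a weaker inhibitor, a lower number a stronger inhibitor), compound 1 gives a value that is only a limit of the assay, > 10000 nM. Compound 2 likewise gives only a limit, > 10000 nM. The step between them is therefore a step that the two limits leave unreadable from compound 1 to compound 2.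

Compound 3 `COc1cc(-n2ncnc2-c2cccc([N+](=O)[O-])c2)cc(OC)c1OC` has the same atoms as compound 1 joined differently; the difference between the two cores is not broken down here. In this assay compound 3 also gives only a limit, > 10000 nM. Compound 4 `COc1cc(-n2ncnc2-c2cccc(Cl)c2)cc(OC)c1OC` is not yet measured and differs from compound 3 by chloro in place of nitro on an aromatic carbon. This is the same kind of change as from compound 1 to compound 2, though the place differs: there the chloro sits para to a large group, here meta to a large group.

Because (the limit of > 10000 nM in this assay, at which 3 of the 3 values shown sit), the step that the limit leaves unreadable from compound 3 to compound 4 is expected to stay unreadable. Compound 4 is estimated at 15000 nM, between 5000 nM and 50000 nM.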

Compound 4, half-maximal inhibitory concentration: > 10000 nM
Compound 4 was reported as a limit; the forecaster's own chance of this, stated with the estimate: 80%; the middle value is on the limit's open side.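

Compound 4, like compound 3, gives only a limit in this assay, so no size can be read for the change from nitro to chloro between compound 3 and compound 4: the limit of > 10000 nM in this assay, at which 4 of the 4 values shown sit.

The compounds shown leave open whether either core, with any of these groups, can give a readable value in this assay and how nitro and chloro compare there.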